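The source may hold more compounds than are shown below. What is called first, only, known or untested is meant among the compounds shown, and "the series" means these compounds.

A small set of compounds built on the same shared core has been examined in an assay on isolated protein for inhibition of matrix metalloproteinase-9 (Mus musculus); a higher number here means a weaker inhibitor, a lower number a stronger inhibitor. Compound 1 `NCc1nc2cc(NC(=O)c3ccccc3OCc3ccccc3)ccc2[nH]1` gives 48000 nM in this assay. Compound 2 `NCc1nc2cc(NCc3ccccc3OCc3ccccc3)ccc2[nH]1`, which has a chain instead of the amide link, gives 13000 nM; 13000 nM; 13000 nM (3 entries) over three repeat entries. Compound 3 `NCc1nc2cc(NC(=O)/C=C/c3c(F)cccc3F)ccc2[nH]1`, carrying a double-bonded chain with a 2,6-difluorophenyl group, gives 75000 nM. Among the single numbers, compound 3 and compound 1 lie within the usual scatter of each other, so neither can be called the weaker inhibitor on these data; all three compounds sit in the weak range of this assay.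

Compound 4 `NCc1nc2cc(NC(=O)/C=C/c3cccnc3)ccc2[nH]1` differs from compound 3 in one place: pyridin-3-yl in place of 2,6-difluorophenyl on a double-bonded chain carbon bound to a double-bonded chain carbon. Within the data shown here, no pair of measured compounds shows this kind of exchange, so there is no step from which its size can be read directly. With every measured compound weak and no evidence that the aromatic group at the end of the chain moves the number much, compound 4 is expected to stay close to compound 3, and the step from compound 3 to compound 4 is expected to be a 1.3-fold lower number from compound 3 to compound 4 (0.10 log units; within the scatter), within the scatter. On that basis compound 4 is estimated to give 60000 nM in this assay, with a plausible range from 20000 nM to 200000 nM.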

Compound 4, half-maximal inhibitory concentration: 85000 nM
For compound 4 the middle estimate is 1.4-fold (0.15 log units) below the measured one; low and high end bracket the measured number.
By their numbers in this assay, from the lowest: compounds 1, 3 and 4 (each within the scatter of the next).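

In this assay, among these compounds, replacing 2,6-difluorophenyl with pyridin-3-yl on a double-bonded chain carbon bound to a double-bonded chain carbon gives a 1.1-fold higher number from compound 3 to compound 4 (0.05 log units; within the scatter), the first direct reading of an exchange at this position. The exchange replaces a carbon-only aromatic ring bearing two fluorine atoms with a smaller aromatic ring containing one nitrogen atom and one hydrogen-bond acceptor, yet the two numbers cannot be told apart, so this pair shows no measurable difference from swapping one of these rings for the other. No independent measurement is available here to explain this result.

Going by these compounds, both groups compared here are six-membered aromatic rings, so it remains open whether an amine, a carboxylic acid or a saturated ring such as cyclohexyl at the end of the chain would give a number clearly different from those of compound 3 and compound 4. Also open, on these data alone, is whether a longer chain between the amide and the ring would shift the number beyond the usual scatter, since a single exchange cannot show how far this position tolerates change.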